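Substituent steps on the terminal phenyl ring of the series

The compounds below may be only part of what the source reports. "The series", "measured", "known", "first", "only" and "open" are said of these compounds alone.

Measured compounds:
compound 1 `COc1ccc(/C=C\C(=O)O)c(OCc2cn(-c3cccc(C#N)c3)nn2)c1CC=C(C)C` — 45500 nM
compound 2 `COc1ccc(/C=C\C(=O)O)c(OCc2cn(-c3ccccc3)nn2)c1CC=C(C)C` — 35000 nM

In a functional assay on PC-3 cells (Homo sapiens) for cytotoxicity, read by MTT assay, with a stated time of 24 h (on this read-out higher numbers stand for weaker inhibition and lower numbers for stronger inhibition), compound 2 stands at the lower of the two numbers shown; its nearest neighbour is compound 1, and the step of a 1.3-fold lower number from compound 1 to compound 2 (0.11 log units; within the scatter) lies within the scatter, so the two values show no difference that can be read as real.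

Compound 3 `COc1ccc(/C=C\C(=O)O)c(OCc2cn(-c3ccc(CO)cc3)nn2)c1CC=C(C)C` is the next step from compound 2: hydroxymethyl in place of hydrogen on an aromatic carbon. Among the measured compounds shown here, the only measured step that bears on a substituent change on this phenyl ring is the one from compound 1 to compound 2, and it was within the scatter. A further substituent on the same ring therefore gives no ground to expect a step beyond the scatter in this assay, in either direction.

Compound 3 is accordingly estimated at 35000 nM, within a range of 15000 nM to 80000 nM, an expected step of no change at the digits printed from compound 2 to compound 3 (within the scatter).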

Compound 3, half-maximal inhibitory concentration: 28300 nM
Estimate against measurement, compound 3: 1.2-fold (0.09 log units) above; the range from low to high includes it.
By their numbers in this assay, from the lowest: compounds 3, 2 and 1 (each within the scatter of the next).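

In this assay, hydroxymethyl on an aromatic carbon para to a large group gives a 1.2-fold lower number from compound 2 to compound 3 (0.09 log units; within the scatter), so a substituent with a hydrogen-bond donor and acceptor at this place produces no difference that can be read as real. The larger swap, 4-(hydroxymethyl)phenyl in place of 3-cyanophenyl, gives a 1.6-fold lower number from compound 1 to compound 3 (0.21 log units; within the scatter) and also stays within the scatter, so the change of substituent together with its place on the ring shows no real difference either. Nothing at hand bears on why these steps are this small.

Going by these compounds, whether any substituent on this phenyl ring can produce a step beyond the scatter remains open. An amine, a carboxylic acid or a longer hydroxyalkyl chain at the same place would test that.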